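A few compounds are considered here, and "the series" means these few. Any claim that something is new, unique, unknown or untested is made for them only; others in the source may bear on it.

Working notes on the series. Compound 1 `CCCc1cc(N)c2cc(NC(=O)c3ccc(-c4ccc(Cl)cc4)cc3)ccc2n1` gives 0.7 nM in an assay on isolated protein for displacement of a labelled ligand from melanin-concentrating hormone receptor 1 (Homo sapiens); a higher number here means a weaker inhibitor, a lower number a stronger inhibitor. Compound 3 `CCCc1cc(N)c2cc(NC(=O)/C=C/c3ccc(SC)cc3)ccc2n1` gives 9 nM. Compound 2 `Nc1cc(-c2ccccc2)nc2ccc(NC(=O)/C=C/c3ccc(C(F)(F)F)cc3)cc12` gives 18.5 nM, the highest of the three numbers; compound 3 is its nearest neighbour, lower by a margin beyond the scatter, and compound 1 lies furthest below it, also beyond the scatter. Compound 4 `Cc1cc(N)c2cc(NC(=O)/C=C/c3ccc(C(F)(F)F)cc3)ccc2n1` is not yet measured. It differs from compound 2 as follows: methyl in place of phenyl on an aromatic carbon. Among the compounds with values here, no pair of measured compounds isolates this change, so the expectation rests on compound 2 giving 18.5 nM while compound 3 giving 9 nM carries the same amide part. A moderate lowering of the number in this assay, beyond the scatter, is expected; the expected step is a 1.9-fold lower number from compound 2 to compound 4 (0.27 log units; within the scatter). Compound 4 is estimated at 10 nM, within 3 nM to 40 nM.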

Compound 4, half-maximal inhibitory concentration: 8 nM
For compound 4 the middle estimate is 1.3-fold (0.10 log units) above the measured one, within the range that was stated.
By their numbers in this assay, from the lowest: compound 1; then compounds 4 and 3 (each within the scatter of the next); then compound 2.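

Within the data shown here, replacing phenyl with methyl on the aromatic carbon next to the ring nitrogen gives a 2.3-fold lower number from compound 2 to compound 4 (0.36 log units; beyond the scatter) in this assay, the only step that isolates this position. With the amide part held constant, the phenyl ring is therefore not required here, and the number does not rise when it is replaced by methyl.

As far as these compounds go, whether an amine, a methoxy group or a longer chain such as butyl is accepted at this carbon remains open, as does whether the same step would hold with a different amide part. Nothing measured here bears on the reason for this step.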